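Swapping the Amine Tail for a Carbamate

The source may hold more compounds than are shown below. What is called first, only, known or untested is meant among the compounds shown, and "the series" means these compounds.

Three measured compounds share one core and differ only in the group on a sulfonyl sulfur. In a physicochemical assay for permeability, using PAMPA, at pH 7.4 (a lower number here means that the compound crosses the layer more slowly, a higher number that the compound crosses the layer faster), compound 1 `CC(C)S(=O)(=O)NC(=O)c1ccc(Nc2nc(NC3(c4ccc(Cl)cc4)CC3)nc(OCC(F)(F)F)n2)cc1` gives 31 nm/s, compound 2 `O=C(NS(=O)(=O)c1ccccc1)c1ccc(Nc2nc(NC3(c4ccc(Cl)cc4)CC3)nc(OCC(F)(F)F)n2)cc1` gives 182 nm/s, and compound 3 `CC(C)(C)CNCCS(=O)(=O)NC(=O)c1ccc(Nc2nc(NC3(c4ccc(Cl)cc4)CC3)nc(OCC(F)(F)F)n2)cc1` gives 651 nm/s, the highest of the three. The steps were a 5.9-fold higher number from compound 1 to compound 2 (0.77 log units; beyond the scatter), a 21-fold higher number from compound 1 to compound 3 (1.32 log units; beyond the scatter) and a 3.6-fold higher number from compound 2 to compound 3 (0.55 log units; beyond the scatter). Compound 4 `COC(=O)NCCS(=O)(=O)NC(=O)c1ccc(Nc2nc(NC3(c4ccc(Cl)cc4)CC3)nc(OCC(F)(F)F)n2)cc1` is not yet measured; it differs from compound 3 by methoxycarbonyl in place of neopentyl on an amine nitrogen. For the measured compounds named here, no measured step touches this amine nitrogen, so the three steps bear on it only loosely. Still, because compound 3 stands apart at 651 nm/s, a move back toward the range of compound 1 and compound 2 is expected, a downward step of an 11-fold lower number from compound 3 to compound 4 (1.04 log units; beyond the scatter). Compound 4 is therefore estimated at 60 nm/s, within 15 nm/s to 250 nm/s.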

Compound 4, apparent permeability: 39 nm/s
Beside the measured number, compound 4's estimate is 1.5-fold (0.19 log units) above it; low and high end bracket the measured number.
By their numbers in this assay, from the lowest: compounds 1 and 4 (each within the scatter of the next); then compound 2; then compound 3.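

For the compounds shown here, this is the first change at the amine nitrogen itself: in this assay, methoxycarbonyl in place of neopentyl gives a large step (a 17-fold lower number from compound 3 to compound 4 (1.22 log units; beyond the scatter)). Set against phenyl on the sulfonyl sulfur, the 2-((methoxycarbonyl)amino)ethyl chain also gives a clear drop (a 4.7-fold lower number from compound 2 to compound 4 (0.67 log units; beyond the scatter)), while against isopropyl it cannot be told apart (a 1.3-fold higher number from compound 1 to compound 4 (0.10 log units; within the scatter)). Nothing measured here gives a reason for these steps. Still open, on these data alone, is where a free primary amine or an acetyl group on this nitrogen would fall, and whether a longer chain carrying methoxycarbonyl would behave the same way.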